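This account rests on a few compounds, and the source may have more. Where it says the series, first, only, none or still open, it means among the compounds named here.

Compound 1 `Cn1cc(-c2nc3ccccc3n2C(=O)c2ccccc2)c2ccccc21` gives 19600 nM in a functional assay on A549 cells (Homo sapiens) for inhibition, read by MTT assay, with a stated time of 24 h; on this read-out lower numbers stand for stronger inhibition of growth and higher numbers for weaker inhibition of growth. Compound 2 `COc1cccc(C(=O)n2c(-c3cn(C)c4ccccc34)nc3ccccc32)c1` gives 10200 nM in this assay. Compound 3 `COc1ccc(C(=O)n2c(-c3cn(C)c4ccc(OC)cc34)nc3ccccc32)cc1` gives 4900 nM in this assay.

Compound 1 and compound 2 differ by methoxy in place of hydrogen on an aromatic carbon, and this gave a 1.9-fold lower number from compound 1 to compound 2 (0.28 log units; within the scatter). Compound 3 and compound 1 have different cores; that difference is not broken down here. Compound 4 `COc1ccc2c(c1)c(-c1nc3ccccc3n1C(=O)c1ccc(OC)c(OC)c1)cn2C` is not yet measured; it differs from compound 3 by methoxy in place of hydrogen on an aromatic carbon. Among the measured compounds shown here, this is the same kind of change as the one from compound 1 to compound 2, but the place is not identical: in compound 4 the entering methoxy is ortho to a methoxy group and meta to a large group, while in compound 2 it is only meta to a large group. Because the earlier step was a 1.9-fold lower number from compound 1 to compound 2 (0.28 log units; within the scatter), a step of similar size is expected, a 1.6-fold lower number from compound 3 to compound 4 (0.21 log units; within the scatter). Compound 4 is therefore estimated at 3000 nM, between 1400 nM and 6500 nM.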

Compound 4, concentration for 50% growth inhibition: 2700 nM
The estimate for compound 4 lay 1.1-fold (0.05 log units) above the measured number, within the range that was stated.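

In this assay, methoxy in place of hydrogen on an aromatic carbon gave a 1.8-fold lower number from compound 3 to compound 4 (0.26 log units; within the scatter). Set beside the earlier step, the same change gave a step of matching size on the second core: the same change on two cores in this assay, a 1.9-fold lower number (0.28 log units; within the scatter) from compound 1 to compound 2 and a 1.8-fold lower number (0.26 log units; within the scatter) from compound 3 to compound 4, 1.1-fold (0.02 log units) apart, within the scatter of two such steps. Each step lies within the scatter, however, so the agreement does not show that methoxy has a real effect on either core, and two cores and two different places cannot show that the change will carry to further cores.

Among the compounds shown here, the only group entering in these steps is methoxy, so it remains open how a hydroxy group, an amine or a carboxylic acid would read at that place in this assay. From the compounds shown here alone, whether a longer chain, such as ethoxy, would give a step of similar size also remains open.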